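A few compounds are considered here, and "the series" means these few. Any claim that something is new, unique, unknown or untested is made for them only; others in the source may bear on it.

Measured in a functional assay on HeLa cells (Homo sapiens) for cytotoxicity, read by sulforhodamine B assay; a higher number here means a weaker inhibitor, a lower number a stronger inhibitor:
- compound 1 `Cc1ccc(S(=O)(=O)NC(C2=CC(=O)c3c(O)ccc(O)c3C2=O)C(C)C)cc1`: 4850 nM
- compound 2 `Cc1ccccc1S(=O)(=O)NC(C1=CC(=O)c2c(O)ccc(O)c2C1=O)C(C)C`: 790 nM
- compound 3 `Cc1ccc(S(=O)(=O)NC(C)C2=CC(=O)c3c(O)ccc(O)c3C2=O)cc1`: 5340 nM

In this assay compound 3 gives 5340 nM. Methyl in place of isopropyl on the saturated chain carbon makes no difference beyond the scatter, with a 1.1-fold higher number from compound 1 to compound 3 (0.04 log units; within the scatter). Compound 2 shows a clearly lower number, 790 nM.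

Compound 4 `Cc1ccccc1S(=O)(=O)NC(C)C1=CC(=O)c2c(O)ccc(O)c2C1=O` differs from compound 3 at one place, (2-methylphenyl in place of 4-methylphenyl on a sulfonyl sulfur), with 2-methylphenyl in place of 4-methylphenyl on a sulfonyl sulfur. The same exchange has been measured once, in the isopropyl series, giving a 6.1-fold lower number from compound 1 to compound 2 (0.79 log units; beyond the scatter), a modest step beyond the scatter. The change from isopropyl to methyl by itself moved the number by no more than the scatter, so a step of similar size and the same direction is expected here, although a single pair supports it. The expected step is a 5.9-fold lower number from compound 3 to compound 4 (0.77 log units; beyond the scatter). For compound 4 the estimate is 900 nM, with an expected range of 350 nM to 2500 nM.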

Compound 4, half-maximal inhibitory concentration: 4490 nM
Estimate against measurement, compound 4: 5.0-fold (0.70 log units) below, outside the stated range (above it).
By their numbers in this assay, from the lowest: compound 2; then compounds 4, 1 and 3 (each within the scatter of the next).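

In this assay, the exchange of 4-methylphenyl for 2-methylphenyl on the sulfonyl sulfur does not carry over from the isopropyl series to the methyl series, giving a 1.2-fold lower number from compound 3 to compound 4 (0.08 log units; within the scatter). The two places therefore do not act independently in these compounds, and among the four only compound 2, which combines 2-methylphenyl with isopropyl, stands apart with a lower number: the same change on two cores in this assay, a 6.1-fold lower number (0.79 log units; beyond the scatter) from compound 1 to compound 2 and a 1.2-fold lower number (0.08 log units; within the scatter) from compound 3 to compound 4, 5.2-fold (0.71 log units) apart, beyond the scatter of two such steps. Seen from the chain carbon, methyl in place of isopropyl, which changed nothing beyond the scatter with 4-methylphenyl, gives a 5.7-fold higher number from compound 2 to compound 4 (0.75 log units; beyond the scatter) with 2-methylphenyl: the same change on two cores in this assay, a 1.1-fold higher number (0.04 log units; within the scatter) from compound 1 to compound 3 and a 5.7-fold higher number (0.75 log units; beyond the scatter) from compound 2 to compound 4, 5.2-fold (0.71 log units) apart, beyond the scatter of two such steps.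

The compounds shown leave open whether this dependence would hold with ethyl or tert-butyl on the chain carbon, or with unsubstituted phenyl on the sulfonyl sulfur. They also cannot tell what underlies the dependence.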